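A few compounds are considered here, and "the series" means these few. Any claim that something is new, unique, unknown or untested is made for them only; others in the source may bear on it.

In an ADME assay on the whole organism with Oryza sativa as the target, tested at 1 uM (on this read-out higher numbers stand for a weaker effect at the one concentration tested and lower numbers for a stronger effect), compound 1, `Cc1cccc(NC(=O)N[C@H](C)c2ccccc2)c1`, gives 98%. Compound 2, `Cc1cccc(NC(=O)N[C@@H](C)c2ccccc2)c1`, gives 100%. Within the data shown here, the only measured step, a number 2 percentage points higher from compound 1 to compound 2 (within the scatter), rests on (the fact that compounds 1 and 2 differ only in the configuration as drawn). The number for compound 2 is the larger of the two measured, but the gap to compound 1 lies within the scatter, so the two compounds cannot be told apart on this read-out.

Compound 3, `COc1cccc(NC(=O)N[C@@H](C)c2ccccc2)c1`, is not yet measured. It differs from compound 2 by methoxy in place of methyl on an aromatic carbon. Among the measured compounds shown here, no measured step involves a change of this kind: the single step known concerns configuration alone and gives no guide to a swap of groups on the ring. With both measured values sitting close to the top of the scale, compound 3 is expected to give about 97%, most likely between 87% and 100%. The expected step is a number 3 percentage points lower from compound 2 to compound 3 (within the scatter), that is, no shift beyond the scatter.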

Compound 3, a percentage reported as activity, at one concentration (the size of the read-out at that concentration, not a potency): 99%
Beside the measured number, compound 3's estimate is 2 percentage points below it; the range from low to high includes it.
By their numbers in this assay, from the lowest: compounds 1, 3 and 2 (each within the scatter of the next).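

In this assay, putting methoxy in place of methyl on the aromatic carbon meta to a large group gives a number 1 percentage points lower from compound 2 to compound 3 (within the scatter), so the two groups cannot be told apart at this position on this read-out. Among these compounds, the earlier compounds spoke only to configuration, whereas this pair is the first to test a swap of groups on the ring, and the entering oxygen and its hydrogen-bond acceptor leave the number within the scatter. No known fact about these compounds bears on this result.

Going by these compounds, all three numbers sit close to the top of the scale, so it remains open whether any group at this place can give a clearly stronger effect. An amine, a carboxylic acid or a longer chain such as butoxy could each answer that, and the compounds shown say nothing about them.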